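Halogen-for-Methyl Swap on the Sulfonyl Aryl Group

This account rests on a few compounds, and the source may have more. Where it says the series, first, only, none or still open, it means among the compounds named here.

Measured compounds:
Compound 1, `Cc1ccc2ncc(S(=O)(=O)c3cc(Cl)cc(Cl)c3)c(N3CCC(C)CC3)c2c1`: 75%
Compound 2, `Cc1cc(C)cc(S(=O)(=O)c2cnc3ccc(C)cc3c2N2CCC(C)CC2)c1`: 80%

Both compounds were tested in an assay on isolated protein for displacement of a labelled ligand from metabotropic glutamate receptor 5 (Homo sapiens), with a stated time of 60 min, tested at 1 uM; a higher number here means more inhibition at the concentration tested (going by the name of the read-out), a lower number less inhibition. Compound 2 gives 80%, the higher of the two numbers, but only by a number 5 percentage points higher from compound 1 to compound 2 (within the scatter), a gap that lies within the scatter, so the two cannot be ordered. Within the data shown here, the one measured step, a number 5 percentage points higher from compound 1 to compound 2 (within the scatter), is the only one that speaks to an exchange of the aryl group on the sulfonyl sulfur, and it shows the inhibition in this assay staying level, within the scatter, across a change from two chlorines to two methyls.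

Compound 3, `Cc1ccc2ncc(S(=O)(=O)c3ccc(F)c(Cl)c3)c(N3CCC(C)CC3)c2c1`, has not yet been measured. It differs from compound 2 as 3-chloro-4-fluorophenyl in place of 3,5-dimethylphenyl on a sulfonyl sulfur. Compound 3 thus returns to a halogenated ring, closer to compound 1 than to compound 2. Because a number 5 percentage points higher from compound 1 to compound 2 (within the scatter) was within the scatter, the step from compound 2 to compound 3 is expected to be no larger than the scatter, estimated at a number 7 percentage points lower from compound 2 to compound 3 (within the scatter). Compound 3 is therefore estimated at 73%, in the range 55% to 88%.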

Compound 3, a percentage reported as inhibition, at one concentration (the size of the read-out at that concentration, not a potency): 93%
Compound 3: middle estimate off by 20 percentage points, on the low side, outside the stated range (above it).
By their numbers in this assay, from the lowest: compounds 1 and 2 (each within the scatter of the next); then compound 3.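

In this assay the aryl group on the sulfonyl sulfur now clearly moves the read-out: 3-chloro-4-fluorophenyl in place of 3,5-dimethylphenyl gives a number 13 percentage points higher from compound 2 to compound 3 (beyond the scatter), and the same group in place of 3,5-dichlorophenyl gives a number 18 percentage points higher from compound 1 to compound 3 (beyond the scatter). This position is therefore not indifferent to the aryl group, even though the two groups exchanged between compound 2 and compound 3 match in heavy atoms, hydrogen-bond donors, hydrogen-bond acceptors and net charge, and halogens alone do not account for the result, since compound 1 carries two chlorines and stays within the scatter of compound 2. No measurement shown here gives a reason for the difference.

The compounds shown leave open whether the higher number needs both halogens of the 3-chloro-4-fluorophenyl group or only one, as a 3-chlorophenyl or a 4-fluorophenyl group would tell, and how a 4-methoxyphenyl group or a pyridyl ring would read on the same sulfonyl sulfur. All three numbers also come from a single concentration, so they give no potency for any of the compounds.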